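This account rests on a few compounds, and the source may have more. Where it says the series, first, only, none or still open, it means among the compounds named here.

Measured in an ADME assay on a cell-free system (serum) for metabolic stability; a lower number here means that the compound disappears faster, a higher number that the compound lasts longer:
- Compound 1 `Cc1ccccc1C(=O)Oc1ccc(O)c(C(C)(C)C)c1`: < 0.25 h (a limit)
- Compound 2 `CC(C)(C)c1cc(OC(=O)c2ccc(N)cc2)ccc1O`: < 0.25 h (a limit)
- Compound 3 `CC(C)(C)c1cc(NC(=O)c2c(Cl)cc(N)cc2Cl)ccc1O`: > 1 h (a limit)

None of these three results is a number. Compound 1 and compound 2 stand together at the limit of < 0.25 h in this assay, at which 2 of the 3 values shown sit, as a limit of the assay. Compound 3 stands at the limit of > 1 h in this assay, at which 1 of the 3 values shown sits, as a limit of the assay.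

The next molecule, compound 4 `CN(c1cc(Cl)c(C(=O)Nc2ccc(O)c(C(C)(C)C)c2)c(Cl)c1)C1CCCCC1`, keeps the core of compound 3 and alters one group. The change is cyclohexyl(methyl)amino in place of amino on an aromatic carbon, and cyclohexyl(methyl)amino in place of amino on an aromatic carbon gives the full count.

Among the compounds with values here, only one measured step is available as a guide, a step that the two limits leave unreadable from compound 1 to compound 2 and it offers no size to carry over. It also concerns a group on a carbonyl carbon, not the place that changes here. Compound 3 with its limit of > 1 h is therefore the main guide.

No step beyond the usual scatter is expected in this assay so compound 4 should stay on the longer-lasting side. The expected change is a step that the limit leaves unreadable from compound 3 to compound 4 as an estimate only. For compound 4 the estimated half-life is 2 h with an expected range from 1 h to 8 h and the assay may well report only a limit again.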

Compound 4, half-life: > 1 h
Compound 4: no number, only a limit (the forecaster's own chance of this, stated with the estimate: 75%); the middle value lies beyond the limit too.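

Within the data shown here, compound 3 and compound 4 both give only a limit, not a number, in this assay, so no step between them can be read. The compounds shown leave open how long either compound actually lasts, and whether cyclohexyl(methyl)amino in place of amino shortens the half-life, lengthens it or leaves it unchanged.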